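Bromo for Chloro on Two Related Cores

The source may report more compounds than this note shows. Statements on the series, on what has been measured and on what is new or still open speak of the compounds shown alone.

Compound 1 `O=C1C(=O)N(CN2CCN(c3ccnc4cc(Cl)ccc34)CC2)c2cc(Cl)ccc21` and compound 2 `O=C1C(=O)N(CN2CCN(c3ccnc4cc(Cl)ccc34)CC2)c2cc(Br)ccc21` share one core. In an ADME assay on MCF-10A cells (Homo sapiens) for cytotoxicity, read by sulforhodamine B assay, with a stated time of 48 h (a higher number here means a weaker inhibitor of growth, a lower number a stronger inhibitor of growth), compound 1 gives 67800 nM, while compound 2 gives 18000 nM. The change between them, (bromo in place of chloro on an aromatic carbon), produced a 3.8-fold lower number from compound 1 to compound 2 (0.58 log units; beyond the scatter). Compound 3 `NC(=S)N/N=C1/C(=O)N(CN2CCN(c3ccnc4cc(Cl)ccc34)CC2)c2cccc(Cl)c21` rests on a different core; the difference between the two cores is not broken down here. In this assay compound 3 gives 19800 nM. Compound 4 `NC(=S)N/N=C1/C(=O)N(CN2CCN(c3ccnc4cc(Cl)ccc34)CC2)c2cccc(Br)c21` carries the same kind of change relative to compound 3, (bromo in place of chloro on an aromatic carbon), though here the place is ortho to a fused ring and meta to a fused ring, whereas in compound 2 the bromo sits meta to a fused ring and para to a fused ring. Because of a 3.8-fold lower number from compound 1 to compound 2 (0.58 log units; beyond the scatter) a step in the same direction is expected, tempered since the cores differ, so the estimated step is a 2.3-fold lower number from compound 3 to compound 4 (0.37 log units; beyond the scatter). Compound 4 is expected to give 8500 nM, with a likely range from 3000 nM to 25000 nM.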

Compound 4, concentration for 50% growth inhibition: 29400 nM
Beside the measured number, compound 4's estimate is 3.5-fold (0.54 log units) below it, outside the stated range (above it).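

In this assay, among the compounds shown here, bromo in place of chloro on an aromatic carbon gave a 1.5-fold higher number from compound 3 to compound 4 (0.17 log units; within the scatter), so on this core the change produces no step that can be told from the scatter. The step did not carry over from the core of compound 1: the same change on two cores in this assay, a 3.8-fold lower number (0.58 log units; beyond the scatter) from compound 1 to compound 2 and a 1.5-fold higher number (0.17 log units; within the scatter) from compound 3 to compound 4, 5.6-fold (0.75 log units) apart, beyond the scatter of two such steps. For the compounds shown here, with only two pairs, and with the bromo at a different place on each core, these data do not separate the role of the core from that of the place on the ring, and they say nothing about any further core.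

The compounds shown leave open how a fluoro or a methoxy group in place of the halogen would read in this assay on either core. They also leave open whether the two cores would still part if the halogen stood at the same place on both.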